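The compounds below may be only part of what the source reports. "The series", "measured", "known", "first", "only" and "open" are said of these compounds alone.

Three compounds share one core and differ only in the groups on the aromatic ring that carries the sulfonyl. In an assay on isolated protein for inhibition of Aromatase (Homo sapiens), read by fluorescence (a lower number here means a stronger inhibitor, a higher number a weaker inhibitor), compound 1 `O=S(=O)(c1ccc(F)c(F)c1)N1CCCC(Cn2ccnc2)C1` gives 43 nM. Compound 2 `O=S(=O)(c1ccc(F)c(F)c1F)N1CCCC(Cn2ccnc2)C1` gives 46 nM in this assay, and compound 3 `O=S(=O)(c1ccc(OC2CCCC2)c(F)c1)N1CCCC(Cn2ccnc2)C1` gives 22 nM. Going from compound 2 to compound 1 means (hydrogen in place of fluoro on an aromatic carbon), and the step was a 1.1-fold lower number from compound 2 to compound 1 (0.03 log units; within the scatter). From compound 1 to compound 3 the step was a 2.0-fold lower number from compound 1 to compound 3 (0.29 log units; within the scatter). The difference between the cores of compound 3 and compound 2 is not broken down here.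

Compound 4 `O=S(=O)(c1ccc(OC2CCCC2)cc1)N1CCCC(Cn2ccnc2)C1` has not yet been measured. It differs from compound 3 by hydrogen in place of fluoro on an aromatic carbon. This is the same kind of change as from compound 2 to compound 1, but the surroundings differ: here the place is ortho to a cyclopentyloxy group and meta to a large group, whereas there it was ortho to a fluoro group, ortho to a large group and meta to a fluoro group. Since the earlier step was within the scatter, the expected step is a 1.3-fold higher number from compound 3 to compound 4 (0.10 log units; within the scatter), resting on a 1.1-fold lower number from compound 2 to compound 1 (0.03 log units; within the scatter). Compound 4 is expected to give about 28 nM, with an estimated range from 12 nM to 70 nM.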

Compound 4, half-maximal inhibitory concentration: 14 nM
For compound 4 the middle estimate is 2.0-fold (0.30 log units) above the measured one; the measured number falls inside the stated range.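

Replacing the fluoro group with hydrogen on the cyclopentyloxy-bearing ring gives a 1.6-fold lower number from compound 3 to compound 4 (0.20 log units; within the scatter) in this assay. Set beside the same change in the other pair of compounds, the two steps cannot be told apart: the same change on two cores in this assay, a 1.1-fold lower number (0.03 log units; within the scatter) from compound 2 to compound 1 and a 1.6-fold lower number (0.20 log units; within the scatter) from compound 3 to compound 4, 1.5-fold (0.17 log units) apart, within the scatter of two such steps

So, in these two pairs, swapping fluoro for hydrogen behaves alike on both cores as far as this assay can tell, and no difference between the cores shows up. This does not show that the change has a real effect on either core, since each step lies within the scatter by itself, and two pairs cannot establish a rule for the wider series.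

On these data alone, the aromatic ring in these compounds carries only fluoro, hydrogen and cyclopentyloxy groups, so it remains open how a chloro group, a nitrile or a carboxylic acid would fare there. As far as these compounds go, it also remains open whether the swap of fluoro for hydrogen would read the same with a methoxy group or an amine in place of the cyclopentyloxy group.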